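A few compounds are considered here, and "the series" means these few. Any claim that something is new, unique, unknown or untested is made for them only; others in the source may bear on it.

Measured compounds:
- compound 1, `CC[C@H](C)[C@H](NC(=O)CN(c1nc(Cl)nc2[nH]cnc12)C1CC1)C(=O)OCc1ccccc1` — 36.3%
- compound 2, `CC(C)C[C@H](NC(=O)CN(c1nc(Cl)nc2[nH]cnc12)C1CC1)C(=O)OCc1ccccc1` — 15.2%
- compound 3, `O=C(CN(c1nc(Cl)nc2[nH]cnc12)C1CC1)N[C@@H](CCC(=O)OCc1ccccc1)C(=O)OCc1ccccc1` — 50%

Of the compounds shown here, three sharing one core have been measured in a functional assay on the whole organism (Tail, strain ICR) with Mus musculus as the target, in the tail flick test, with a stated time of 90 min, at a dose of 25 umol/kg by the oral route; a lower number here means a weaker effect, a higher number a stronger effect of the compound at the dose given. Compound 3 stands highest of the three; compound 1 lies a number 13.7 percentage points higher from compound 1 to compound 3 (beyond the scatter), and compound 2, the lowest, lies a number 34.8 percentage points higher from compound 2 to compound 3 (beyond the scatter). Both gaps are beyond the scatter, so compound 3 can be called the most active of the set.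

Compound 4, `NC(=O)C[C@H](NC(=O)CN(c1nc(Cl)nc2[nH]cnc12)C1CC1)C(=O)OCc1ccccc1`, has not been measured. It differs from compound 3 by carbamoyl in place of (benzyloxycarbonyl)methyl on a saturated chain carbon, two bonds along the chain from an amide-type nitrogen and a carbonyl carbon.

For the measured compounds named here, no measured step covers this exact change. Going by the values given here, the steps that bear on it are the two that alter the same side chain: a number 34.8 percentage points higher from compound 2 to compound 3 (beyond the scatter) and a number 13.7 percentage points higher from compound 1 to compound 3 (beyond the scatter), and the step of a number 21.1 percentage points lower from compound 1 to compound 2 (beyond the scatter). All three show that the read-out at this position moves markedly with the side chain, and that the benzyl-ester-bearing chain of compound 3 gave the highest number. Taking away that chain in favour of the much smaller carbamoyl is therefore expected to cost activity, by a step of a number 20 percentage points lower from compound 3 to compound 4 (beyond the scatter) in this assay.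

Compound 4 is accordingly estimated at 30%, with a range from 10% to 50%.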

Compound 4, a percentage reported as activity, at one dose (the size of the read-out at that dose, not a potency): 32.3%
Compound 4: the middle estimate sits 2.3 percentage points below what was measured, within the range that was stated.
By their numbers in this assay, from the lowest: compound 2; then compounds 4 and 1 (each within the scatter of the next); then compound 3.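

In this assay, carbamoyl in place of (benzyloxycarbonyl)methyl gave a number 17.7 percentage points lower from compound 3 to compound 4 (beyond the scatter), yet the same group in place of isopropyl gave a number 17.1 percentage points higher from compound 2 to compound 4 (beyond the scatter), so a side chain without the benzyl ester and its aromatic ring can still stand clear of the lowest compound in the set. The comparison with the sec-butyl compound adds a further point: carbamoylmethyl in place of sec-butyl gave a number 4 percentage points lower from compound 1 to compound 4 (within the scatter), so these two different chains cannot be told apart at this dose, and a carbamoyl-bearing chain is no route to the level of compound 3 in this series. No measurement that would explain these differences in the read-out is available.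

The step to compound 4 shortens the chain and replaces the benzyl ester in a single change, so the compounds shown leave open how much of the change in read-out belongs to each. They also leave open how a carboxylic acid or an amine at the end of this chain would read, and whether a longer chain ending in carbamoyl would stand nearer to compound 3 or to compound 4.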